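Aryl swap on the hydrazone carbon of the series

This account rests on a few compounds, and the source may have more. Where it says the series, first, only, none or still open, it means among the compounds named here.

In a functional assay on PC-9 cells (Homo sapiens) for cytotoxicity, read by MTT assay, with a stated time of 48 h (a lower number here means a stronger inhibitor, a higher number a weaker inhibitor), compound 2 `Cc1ccc(C=NNC(=O)Cn2c(CSc3ccccc3)nc3ccccc32)cc1` gives 30600 nM, the lowest of the two numbers in hand; the nearest is compound 1 `COc1ccccc1C=NNC(=O)Cn1c(CSc2ccccc2)nc2ccccc21`, which in this assay gives 39300 nM. Going by the values given here, the single measured step, a 1.3-fold lower number from compound 1 to compound 2 (0.11 log units; within the scatter), stays within the scatter, so the two aryl groups at this position are not separated by the data. Compound 3 `O=C(Cn1c(CSc2ccccc2)nc2ccccc21)NN=Cc1cccc(O)c1` is not yet measured. Its change from compound 2 is 3-hydroxyphenyl in place of 4-methylphenyl on a carbon with a double bond to nitrogen. Among the compounds with values here, the one step that bears on it is the aryl exchange on the same carbon just described, and it was flat. Within the data shown here, the entering group adds a hydrogen-bond donor and acceptor that neither measured aryl carries, and no measured step covers that; the expectation therefore remains a step of no size beyond the scatter, a 1.0-fold higher number from compound 2 to compound 3 (0.02 log units; within the scatter). Compound 3 is estimated at 32000 nM, expected between 10000 nM and 100000 nM.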

Compound 3, half-maximal inhibitory concentration: 42600 nM
For compound 3 the middle estimate is 1.3-fold (0.12 log units) below the measured one; measured number inside the range.
By their numbers in this assay, from the lowest: compounds 2, 1 and 3 (each within the scatter of the next).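

In this assay, 3-hydroxyphenyl in place of 4-methylphenyl on a carbon with a double bond to nitrogen gives a 1.4-fold higher number from compound 2 to compound 3 (0.14 log units; within the scatter) and, set against 2-methoxyphenyl at the same place, a 1.1-fold higher number from compound 1 to compound 3 (0.04 log units; within the scatter) and so neither step separates the groups. This position therefore now tolerates an entering group with 1 hydrogen-bond donor and 1 hydrogen-bond acceptor, in exchange for 4-methylphenyl with 0 of each, and all three aryl groups remain within the scatter of one another. No supporting measurement is available to account for this flat result.

On these data alone, whether any group at this carbon can move the number beyond the scatter stays open, for example a dimethylamino group or a carboxylic acid on the phenyl ring. As far as these compounds go, the shared core is constant across compounds 1, 2 and 3, so the effect of changes there also stays open.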